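Swapping a Furan for a Thiophene on a Shared Core

The source may hold more compounds than are shown below. What is called first, only, known or untested is meant among the compounds shown, and "the series" means these compounds.

Of the compounds shown here, three have been tested in a functional assay on the whole organism (plasma, strain Sprague-Dawley) with Rattus norvegicus as the target, with a stated time of 2 h, at a dose of 50 mg/kg by the oral route; a higher number here means a stronger effect of the compound at the dose given, a lower number a weaker effect. Compound 1 `c1ccc(C(/N=C2\CCCCCCN2)C2CC2)cc1` gives 46%, compound 2 `c1ccc(C(/N=C2\CCCCCN2)c2ccco2)cc1` gives 37%, and compound 3 `c1ccc(C(/N=C2\CCCCCCN2)c2ccco2)cc1` gives 42%. Compound 3 stands second highest of the three numbers; its nearest neighbour is compound 1, whose value is higher by an amount within the scatter, and its furthest is compound 2, whose value is lower, again within the scatter. Among the compounds with values here, the only single-point step among the measured compounds, a number 4 percentage points lower from compound 1 to compound 3 (within the scatter), put a furan-2-yl in place of a cyclopropyl and left the read-out essentially unchanged.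

Compound 4 `c1ccc(C(/N=C2\CCCCCCN2)c2cccs2)cc1` is not yet measured. It differs from compound 3 in one place: thiophen-2-yl in place of furan-2-yl on a saturated chain carbon bound to an aromatic carbon and a double-bonded nitrogen. Within the data shown here, no measured pair exchanges a furan-2-yl for a thiophen-2-yl, so the data offer no direct guide. Among the measured compounds shown here, the one step that touches this position, from compound 1 to compound 3, stayed within the scatter even though the groups exchanged there were quite unlike each other. The change to compound 4 is smaller in kind, swapping one five-membered aromatic ring with one hetero atom for another of the same size. The expectation is therefore a step of no change at the digits printed from compound 3 to compound 4 (within the scatter), that is, nothing beyond the scatter. Compound 4 is estimated at 42%, within a range from 28% to 56%.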

Compound 4, a percentage reported as inhibition, in the whole organism at one dose (the size of the read-out at that dose, not a potency): 37%
For compound 4 the middle estimate is 5 percentage points above the measured one; the range from low to high includes it.
By their numbers in this assay, from the lowest: compounds 2, 4, 3 and 1 (each within the scatter of the next).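

In this assay this position now carries three groups on the same core, and the direct exchange of one five-membered aromatic ring for the other, with sulfur taking the place of oxygen, gives a number 5 percentage points lower from compound 3 to compound 4 (within the scatter) as its step. The exchange of cyclopropyl for thiophen-2-yl gives a number 9 percentage points lower from compound 1 to compound 4 (within the scatter) as its step, so cyclopropyl, furan-2-yl and thiophen-2-yl all lie within the scatter of one another, and this read-out does not separate them at the dose given. Nothing measured here offers an explanation for how closely these groups read, so the result stands as an observation only.

The compounds shown leave open whether the position is as undemanding for groups of a different kind, such as a carboxylic acid, an amine or a longer chain, since only these three groups have been compared on this core. They also leave open whether thiophen-2-yl and furan-2-yl would still read alike on the core of compound 2, and whether a full dose-response comparison would separate any of these compounds, given that each value describes a single dose and not a potency.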